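The compounds below may be only part of what the source reports. "The series", "measured", "known", "first", "only" and "open" are said of these compounds alone.

Compound 1: `Nc1ccc(/C=C2\SC(=O)N(Cc3cccc(Cl)c3)C2=O)cc1` — 18000 nM
Compound 2: `Nc1ccc(/C=C2\SC(=O)N(Cc3ccc(F)cc3)C2=O)cc1` — 111000 nM
Compound 3: `C=C(Br)C(=O)Nc1ccc(/C=C2\SC(=O)N(Cc3ccc(F)cc3)C2=O)cc1` — 2400 nM

These three compounds were tested in a functional assay on CCRF-CEM cells (Homo sapiens) for cytotoxicity, read by cell counting, with a stated time of 3 days; a higher number here means a weaker inhibitor, a lower number a stronger inhibitor. Compound 2 gives the highest number of the three, and compound 3 the lowest. The move from compound 2 to compound 1 is a single change, (3-chlorophenyl in place of 4-fluorophenyl on a saturated chain carbon bound to an amide-type nitrogen in a ring), and it brought a 6.2-fold lower number from compound 2 to compound 1 (0.79 log units; beyond the scatter). The move from compound 2 to compound 3 is also a single change, ((1-bromoethenyl)carbonyl in place of hydrogen on a nitrogen on an aromatic ring), and it brought a 46-fold lower number from compound 2 to compound 3 (1.67 log units; beyond the scatter).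

Compound 4, `C=C(Br)C(=O)Nc1ccc(/C=C2\SC(=O)N(Cc3cccc(Cl)c3)C2=O)cc1`, has not yet been measured in this assay. It differs from compound 3 by 3-chlorophenyl in place of 4-fluorophenyl on a saturated chain carbon bound to an amide-type nitrogen in a ring. This is the same change that separates compound 2 from compound 1, made on a core that differs from theirs by (1-bromoethenyl)carbonyl in place of hydrogen on a nitrogen on an aromatic ring. If the step repeats on this second core, compound 4 is expected to come in at a 4.8-fold lower number from compound 3 to compound 4 (0.68 log units; beyond the scatter) relative to compound 3, because the earlier instance gave a 6.2-fold lower number from compound 2 to compound 1 (0.79 log units; beyond the scatter). Among the measured compounds shown here, whether the step carries over fully is uncertain with only one prior example. The estimated value for compound 4 is 500 nM, with a likely range from 150 nM to 1500 nM.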

Compound 4, half-maximal inhibitory concentration: 3700 nM
For compound 4 the middle estimate is 7.4-fold (0.87 log units) below the measured one, and the stated range ends below it.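

In this assay, the swap of 4-fluorophenyl for 3-chlorophenyl did not carry over from one core to the other: on the core with the (1-bromoethenyl)carbonyl group it gave a 1.5-fold higher number from compound 3 to compound 4 (0.19 log units; within the scatter), a difference too small to count as a real change, and the two instances disagree: the same change on two cores in this assay, a 6.2-fold lower number (0.79 log units; beyond the scatter) from compound 2 to compound 1 and a 1.5-fold higher number (0.19 log units; within the scatter) from compound 3 to compound 4, 9.5-fold (0.98 log units) apart, beyond the scatter of two such steps. Read the other way, adding the (1-bromoethenyl)carbonyl group still lowered the number on the 3-chlorophenyl side, giving a 4.9-fold lower number from compound 1 to compound 4 (0.69 log units; beyond the scatter), but that gain was much smaller than on the 4-fluorophenyl side: the same change on two cores in this assay, a 46-fold lower number (1.67 log units; beyond the scatter) from compound 2 to compound 3 and a 4.9-fold lower number (0.69 log units; beyond the scatter) from compound 1 to compound 4, 9.5-fold (0.98 log units) apart, beyond the scatter of two such steps. So the two changes do not simply add up in this series, and a step seen on one core cannot be assumed on the other, but a single set of four compounds does not show why, or whether other groups would behave the same way.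

As far as these compounds go, it remains open how a plain phenyl or a methoxyphenyl in the same place would respond on each core. From the compounds shown here alone, it is also open whether an ethenylcarbonyl group without the bromine would lower the number as well.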